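Swapping One Amide Group on a Shared Core

The compounds below may be only part of what the source reports. "The series", "measured", "known", "first", "only" and "open" are said of these compounds alone.

In an ADME assay on HeLa cells (Homo sapiens) for cytotoxicity, read by MTT assay (a higher number here means a weaker inhibitor, a lower number a stronger inhibitor), three compounds built on a shared core differ only in the group on a carbonyl carbon. Compound 1 `COC(=O)[C@@H]1CCCN1C(=O)CCC(=O)Oc1ccc(C[C@H]2C(=O)OC[C@@H]2Cc2ccc(OC)c(OC)c2)cc1OC` gives 145000 nM here. Compound 2 `CCN(CC)C(=O)CCC(=O)Oc1ccc(C[C@H]2C(=O)OC[C@@H]2Cc2ccc(OC)c(OC)c2)cc1OC` gives 213000 nM here. Compound 3 `CCN1CCN(C(=O)CCC(=O)Oc2ccc(C[C@H]3C(=O)OC[C@@H]3Cc3ccc(OC)c(OC)c3)cc2OC)CC1` gives 190000 nM here, which places it within the usual scatter of both other compounds, so this measurement cannot rank the three.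

Compound 4 `COC(=O)[C@H](CCSC)NC(=O)CCC(=O)Oc1ccc(C[C@H]2C(=O)OC[C@@H]2Cc2ccc(OC)c(OC)c2)cc1OC` has not been measured yet. The swap (1-(methoxycarbonyl)-3-(methylsulfanyl)propyl)amino in place of 4-ethylpiperazin-1-yl on a carbonyl carbon leads to it and puts (1-(methoxycarbonyl)-3-(methylsulfanyl)propyl)amino in place of 4-ethylpiperazin-1-yl on a carbonyl carbon.

Three measured swaps at that same place bear on this one. They are a 1.5-fold higher number from compound 1 to compound 2 (0.17 log units; within the scatter) and a 1.3-fold higher number from compound 1 to compound 3 (0.12 log units; within the scatter) and a 1.1-fold lower number from compound 2 to compound 3 (0.05 log units; within the scatter) and each stays within the scatter. None of them brings in the entering group, so the guidance is only indirect. Compound 1, whose group also holds a methoxycarbonyl, gives 145000 nM and serves as the closest guide.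

An estimated step of a 1.2-fold lower number from compound 3 to compound 4 (0.06 log units; within the scatter) is expected, which means no step beyond the scatter. The estimated value for compound 4 is 165000 nM with an expected range from 85000 nM to 300000 nM in repeated measurements.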

Compound 4, half-maximal inhibitory concentration: 199000 nM
For compound 4 the middle estimate is 1.2-fold (0.08 log units) below the measured one; the range from low to high includes it.
By their numbers in this assay, from the lowest: compounds 1, 3, 4 and 2 (each within the scatter of the next).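

Compound 4 brings to this carbonyl carbon a group unlike the others shown, an open chain with a sulfur atom, a methoxycarbonyl and a hydrogen-bond donor, where 4-ethylpiperazin-1-yl has a ring and no donor. Even so, this assay shows a 1.0-fold higher number from compound 3 to compound 4 (0.02 log units; within the scatter), along with a 1.1-fold lower number from compound 2 to compound 4 (0.03 log units; within the scatter) and a 1.4-fold higher number from compound 1 to compound 4 (0.14 log units; within the scatter), so the four compounds cannot be told apart and the earlier finding now extends to a group with a defined stereocentre and a sulfur atom. No information is available on what lies behind this lack of separation among the four groups.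

What remains open is whether any group on this carbonyl carbon can produce a step beyond the scatter, since all the groups shown are uncharged amino groups that form amides with that carbon. A free carboxylic acid in place of the methoxycarbonyl, a primary amine at the end of the chain, or a longer chain carrying a phenyl ring would test that question, and the compounds shown say nothing about how any of these would read.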